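Thioether series: from phenethyl to 3,5-dimethylphenyl on sulfur

The source may report more compounds than this note shows. Statements on the series, on what has been measured and on what is new or still open speak of the compounds shown alone.

In a functional assay on HeLa cells (Homo sapiens) for inhibition, read by CCK-8 assay, with a stated time of 72 h, tested at 8 uM (on this read-out lower numbers stand for less inhibition of growth and higher numbers for more inhibition of growth at the one concentration tested), the measured compounds read as follows
- compound 1 `COc1ccc(SCc2ccc(C(=O)Nc3ccccc3N)cc2)cc1` gives 79.7%
- compound 2 `Nc1ccccc1NC(=O)c1ccc(CSc2cccc(F)c2)cc1` gives 78.4%
- compound 3 `Nc1ccccc1NC(=O)c1ccc(CSCCc2ccccc2)cc1` gives 74.8%

Not yet measured: compound 4 `Cc1cc(C)cc(SCc2ccc(C(=O)Nc3ccccc3N)cc2)c1`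

Compound 3 at 74.8% stands level with the other two compounds within the scatter. The move to compound 4 is 3,5-dimethylphenyl in place of phenethyl on a sulfur with 3,5-dimethylphenyl in place of phenethyl on a sulfur. Among the compounds with values here, no measured compound carries 3,5-dimethylphenyl itself. The nearest evidence is a number 4.9 percentage points lower from compound 1 to compound 3 (within the scatter) and a number 3.6 percentage points lower from compound 2 to compound 3 (within the scatter) with phenethyl entering in place of a substituted phenyl, the reverse kind of change. A swap of one substituted phenyl for another appears in a number 1.3 percentage points lower from compound 1 to compound 2 (within the scatter) and it is just as small. All three steps lie within the scatter, so no step beyond the scatter is expected here. In this assay the expected change is a number 3.2 percentage points higher from compound 3 to compound 4 (within the scatter) and this estimate leans towards the values of the two phenyl thioethers. For compound 4 the estimated value is 78% within an expected range of 69% to 86% in this read-out.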

Compound 4, percent growth inhibition at one concentration: 78.9%
Estimate against measurement, compound 4: 0.9 percentage points below; the measured number falls inside the stated range.
By their numbers in this assay, from the lowest: compounds 3, 2, 4 and 1 (each within the scatter of the next).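

Within this assay, the swap of phenethyl for 3,5-dimethylphenyl, two groups with the same atom count, leaves the reading within the scatter (a number 4.1 percentage points higher from compound 3 to compound 4 (within the scatter)). A phenyl carrying only carbon substituents also stands level with the fluorine-bearing and methoxy-bearing phenyl thioethers (a number 0.5 percentage points higher from compound 2 to compound 4 (within the scatter); a number 0.8 percentage points lower from compound 1 to compound 4 (within the scatter)), so all four groups on this sulfur are now indistinguishable at the one concentration tested. Nothing at hand explains this flat reading.

The compounds shown leave open whether any group on this sulfur can move the number beyond the scatter, and a phenyl carrying an amine or a carboxylic acid would test that, as would a longer chain than phenethyl. With one concentration only, they also leave open whether the four compounds would separate across a range of concentrations.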